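Series notes: from compound 2 to compound 3

The source may hold more compounds than are shown below. What is called first, only, known or untested is meant among the compounds shown, and "the series" means these compounds.

Measured in an assay on liver (Sus scrofa) for inhibition of glucose-6-phosphatase catalytic subunit 1 (Homo sapiens), using microsomes; on this read-out higher numbers stand for weaker inhibition and lower numbers for stronger inhibition:
compound 1 `c1ccc(CN(Cc2ccccc2)/N=C2\CCCc3ccccc32)cc1`: 25000 nM
compound 2 `Clc1ccc(/C=N/N(Cc2ccccc2)Cc2ccccc2)cc1Cl`: 2000 nM

Compound 2 holds the lower of the two numbers in this assay; the gap up to compound 1 is beyond the usual scatter, so the two are distinguishable on this read-out. Compound 1 and compound 2 differ in more than one place, and no single step between them is worked out, so the two values are simply shown side by side.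

The next compound is compound 3 `O=[N+]([O-])c1ccc(/C=N/N(Cc2ccccc2)Cc2ccccc2)o1`. It differs from compound 2 in one place: 5-nitrofuran-2-yl in place of 3,4-dichlorophenyl on a carbon with a double bond to nitrogen. Within the data shown here, nothing among the measured compounds speaks to this kind of exchange, so no firm direction can be read off. The step from compound 2 to compound 3 in this assay is expected to be small, a 2.0-fold higher number from compound 2 to compound 3 (0.30 log units; within the scatter), with a slight lean toward a higher number. Compound 3 is estimated at 4000 nM, within a range of 1000 nM to 16000 nM.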

Compound 3, half-maximal inhibitory concentration: > 100000 nM
Compound 3: no number, only a limit; the forecaster's own chance of this, stated with the estimate: 10%; at least 25-fold (1.39 log units) between middle value and limit.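

On the carbon with a double bond to nitrogen, the group cannot be exchanged freely in this assay: 5-nitrofuran-2-yl in place of 3,4-dichlorophenyl gives an at least 50-fold higher number from compound 2 to compound 3 (1.69 log units; beyond the scatter). Among these compounds, this is the first single-place step, and it shows that this position responds strongly to the group it carries, even though the two groups are equal in heavy-atom count. Compound 3 carries only a limit of the assay and not a number, so the step has a lower bound but no exact size: the limit of > 100000 nM in this assay, at which 1 of the 3 values shown sits.

The compounds shown do not separate the nitro group from the furan ring, and a plain furan ring or a nitro group on a phenyl ring would do so. Also open, on these data alone, is whether an amine or a carboxylic acid at this place would stay close to compound 2 at 2000 nM.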